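The source may report more compounds than this note shows. Statements on the series, on what has been measured and on what is new or still open speak of the compounds shown alone.

Compound 2 `Nc1scc(CN2CCN(c3cccc4ccccc34)CC2)c1C(=O)c1ccc(Cl)cc1` holds the higher of the two numbers in a functional assay on CHO cells with adenosine receptor A1 (Homo sapiens) as the target, read by cAMP accumulation and immunoassay, with a stated time of 6 min, tested at 1 uM (on this read-out higher numbers stand for a weaker effect at the one concentration tested and lower numbers for a stronger effect), where compound 2 gives 2.9%. Compound 1 `Nc1scc(CN2CCN(c3ccc(Cl)cc3Cl)CC2)c1C(=O)c1ccc(Cl)cc1` gives -54%. Among the compounds with values here, the only measured step runs between these two: a number 56.9 percentage points higher from compound 1 to compound 2 (beyond the scatter). Compound 3 `Nc1scc(CN2CCN(c3ccc(F)c(Cl)c3)CC2)c1C(=O)c1ccc(Cl)cc1` brings (3-chloro-4-fluorophenyl in place of naphthalen-1-yl on an amine nitrogen in a ring). Compound 3 thus carries one six-membered aromatic ring with a chlorine and a fluorine, built more like compound 1 than compound 2, so a move back toward compound 1 is expected. For compound 3 the estimated step is a number 32.9 percentage points lower from compound 2 to compound 3 (beyond the scatter), a sizeable fall. Compound 3 is expected to give -30%, within -65% to 5%.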

Compound 3, a percentage reported as activity, at one concentration (the size of the read-out at that concentration, not a potency): -60%
The estimate for compound 3 lay 30 percentage points above the measured number; the range from low to high includes it.
By their numbers in this assay, from the lowest: compounds 3 and 1 (each within the scatter of the next); then compound 2.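

In this assay there is a number 62.9 percentage points lower from compound 2 to compound 3 (beyond the scatter), and a number 6 percentage points lower from compound 1 to compound 3 (within the scatter), so the two chlorinated phenyl groups on this amine nitrogen cannot be told apart. Among these three compounds, the low number is therefore not tied to one halogen arrangement, and compound 2, with naphthalen-1-yl, alone stands apart. Nothing available explains this difference. From the compounds shown here alone, what a plain phenyl or a methoxyphenyl group would give at this position stays open, and so does whether the low numbers need a halogen at all.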